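The source may report more compounds than this note shows. Statements on the series, on what has been measured and on what is new or still open speak of the compounds shown alone.

Two numbers exist so far for this series. In an ADME assay on HOP-62 cells (Homo sapiens) for cytotoxicity, read by sulforhodamine B assay, with a stated time of 24 h (a lower number here means that less compound is tolerated, a higher number that more compound is tolerated), compound 1 `COc1ccc(C(=O)/C=C/c2cc3ccccc3[nH]c2=O)cc1` gives 59000 nM, and compound 2 `O=C(/C=C/c1cc2ccccc2[nH]c1=O)c1ccc(O)cc1` gives 85200 nM. Within the data shown here, the single step between them, a 1.4-fold higher number from compound 1 to compound 2 (0.16 log units; within the scatter), lies within the scatter, so compound 2 cannot be set apart from compound 1 on these data; the two sit together within the usual spread of repeated runs.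

Compound 3 `O=C(/C=C/c1cc2ccccc2[nH]c1=O)c1ccc(Cl)cc1` differs from compound 2 by chloro in place of hydroxy on an aromatic carbon, para to a large group. Among the measured compounds shown here, the only measured step, a 1.4-fold higher number from compound 1 to compound 2 (0.16 log units; within the scatter), also alters the substituent at this same aromatic carbon and produced no shift beyond the scatter. For the measured compounds named here, no step involving chloro has been measured, so the direction of the change cannot be read from the series; the one comparable alteration at this position left this assay essentially unchanged. The expected step is therefore a 1.3-fold lower number from compound 2 to compound 3 (0.12 log units; within the scatter), with no direction beyond the scatter. Compound 3 is estimated at 65000 nM, within a range of 25000 nM to 160000 nM.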

Compound 3, concentration lethal to 50% of the cells: > 100000 nM
Compound 3: no number, only a limit; the forecaster's own chance of this, stated with the estimate: 15%; middle value at least 1.5-fold (0.18 log units) away from the limit.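

In this assay compound 3 gives > 100000 nM, which is a limit of the assay and not a number. Its two steps, an at least 1.1-fold higher number from compound 2 to compound 3 (0.06 log units; that floor lies within the scatter) and an at least 1.6-fold higher number from compound 1 to compound 3 (0.22 log units; that floor lies within the scatter), are floors only: each lies within the scatter, so on these data chloro cannot be set apart from hydroxy or methoxy on this aromatic carbon, para to a large group, although the true gaps may be wider. What is new for this position is that a substituent without oxygen, with 0 hydrogen-bond donors and 0 hydrogen-bond acceptors, does not bring the number down, and the series now reaches the end of the range that can be read as a number: the limit of > 100000 nM in this assay, at which 1 of the 3 values shown sits.

Still open, on these data alone, is how far compound 3 really lies from compound 1 and compound 2, since only a floor exists for both gaps. Also open, as far as these compounds go, is whether this carbon stays as undemanding with a group of another kind, such as an amine or a carboxylic acid, and what any change to the shared core would do, as all three compounds vary this one substituent only.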